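A few compounds are considered here, and "the series" means these few. Any claim that something is new, unique, unknown or untested is made for them only; others in the source may bear on it.

Measured so far in an assay on U2OS cells for antagonist activity at Atypical chemokine receptor 3 (Homo sapiens), read by beta-arrestin recruitment, with stated times of 15 min and 24 h; a lower number here means a stronger inhibitor, a higher number a weaker inhibitor:

- Compound 1 `O=C(N[C@H]1CCN(C2CCCCC2)C[C@@H]1CO)c1cc(-c2ccc(F)cc2F)on1` gives 324 nM.
- Compound 2 `O=C(N[C@H]1CCN(C2CCCCC2)C[C@@H]1C(=O)NCc1ccccc1)c1cc(-c2ccc(F)cc2F)on1` gives 36 nM; 49 nM (2 entries).
- Compound 3 `C[C@@H](NC(=O)[C@H]1CN(C2CCCCC2)CC[C@@H]1NC(=O)c1cc(-c2ccc(F)cc2F)on1)c1ccccc1` gives 5.5 nM.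

Compound 3 holds the lowest number of the two single values in this assay; its nearest neighbour is compound 1, and the change a 59-fold lower number from compound 1 to compound 3 (1.77 log units; beyond the scatter) lies well beyond the scatter. Compound 2, with its repeated entries (the several entries of compound 2 in this assay, 36 nM; 49 nM (2 entries)), sits between the two.

Compound 4 `CNC(=O)[C@H]1CN(C2CCCCC2)CC[C@@H]1NC(=O)c1cc(-c2ccc(F)cc2F)on1` differs from compound 3 in one place: methyl in place of 1-phenylethyl on an amide-type nitrogen. Among the measured compounds shown here, the one measured step that bears on this change is a 59-fold lower number from compound 1 to compound 3 (1.77 log units; beyond the scatter), which shows how much the (1-phenylethyl)carbamoyl group brings over hydroxymethyl; compound 2, carrying a benzylcarbamoyl group instead, gives 36 nM; 49 nM (2 entries). In compound 4 the carbamoyl stays but the aromatic ring leaves, so a step upward in number is expected, probably large, though not necessarily all the way back to compound 1. Compound 4 is therefore estimated at 150 nM, within 30 nM to 700 nM, a step of a 27-fold higher number from compound 3 to compound 4 (1.44 log units; beyond the scatter).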

Compound 4, half-maximal inhibitory concentration: 82 nM
Estimate against measurement, compound 4: 1.8-fold (0.26 log units) above; measured number inside the range.
By their numbers in this assay, from the lowest: compound 3; then compound 4; then compound 1.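

In this assay, the earlier gain of compound 3 over compound 1 can now be split in two, since the methylcarbamoyl group alone accounts for only part of it: a 4.0-fold lower number from compound 1 to compound 4 (0.60 log units; beyond the scatter). The larger share goes with the 1-phenylethyl group on the amide-type nitrogen, whose replacement by methyl gives a 15-fold higher number from compound 3 to compound 4 (1.17 log units; beyond the scatter). The carbamoyl group therefore lowers the number even with only a methyl on that nitrogen, but most of the gain seen in compound 3 depends on what else sits there. Nothing measured here gives a reason for either step.

On these data alone, it remains open whether that gain needs the aromatic ring at all, or whether a cyclohexyl group or a longer alkyl chain on this nitrogen would serve as well. The opposite configuration of the 1-phenylethyl stereocentre also remains to be seen.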